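This account rests on a few compounds, and the source may have more. Where it says the series, first, only, none or still open, it means among the compounds named here.

Measured compounds:
- compound 1, `C=CCOC[C@H]1CN(C)CC[C@@H]1c1ccc(Cl)cc1`, 60 nM
- compound 2, `CN1CC[C@H](c2ccc(Cl)cc2)[C@@H](CC(=O)N(C)C)C1`, 16 nM
- compound 3, `CN1CC[C@H](c2ccc(Cl)cc2)[C@@H](CCC(=O)Nc2ccccc2)C1`, 201 nM

All three share one core and differ only in the side chain on the saturated ring carbon. In an assay on striatum with sodium-dependent dopamine transporter (Rattus norvegicus) as the target (a higher number here means a weaker inhibitor, a lower number a stronger inhibitor), compound 1 stands second highest of the three numbers. Its nearest neighbour is compound 3, whose value is higher; the gap between compound 1 and compound 3 lies beyond the scatter. For the measured compounds named here, compound 2 gives the lowest number, and the one step recorded, a 3.8-fold lower number from compound 1 to compound 2 (0.57 log units; beyond the scatter), is modest but also beyond the scatter.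

Compound 4, `CN1CC[C@H](c2ccc(Cl)cc2)[C@@H](CCCF)C1`, is not yet measured in this assay. It differs from compound 1 as follows: 2-fluoroethyl in place of allyloxy on a saturated chain carbon bound to a saturated ring carbon. Going by the values given here, no recorded step bears directly on this change; the step from compound 1 to compound 2 exchanges the allyloxy for a dimethylcarbamoyl rather than for a 2-fluoroethyl, and the values of compound 2 and compound 3 only show that side chains of quite different make-up span a range of several steps around compound 1. With nothing closer to lean on, the expectation for compound 4 is a number near that of compound 1, with no step beyond the scatter in either direction: a 1.2-fold lower number from compound 1 to compound 4 (0.08 log units; within the scatter). The estimate for compound 4 is 50 nM, in a range from 15 nM to 180 nM.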

Compound 4, inhibition constant: 43 nM
Beside the measured number, compound 4's estimate is 1.2-fold (0.07 log units) above it; measured number inside the range.
By their numbers in this assay, from the lowest: compound 2; then compounds 4 and 1 (each within the scatter of the next); then compound 3.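

In this assay, the exchange gives a 1.4-fold lower number from compound 1 to compound 4 (0.14 log units; within the scatter), so on a saturated chain carbon bound to a saturated ring carbon, the double bond and the hydrogen-bond acceptor counted for allyloxy can both go, and 2-fluoroethyl, with 0 hydrogen-bond acceptors, can enter, without the number leaving the scatter. The same place is not indifferent to every exchange: the other new pair shows a 2.7-fold higher number from compound 2 to compound 4 (0.43 log units; beyond the scatter), a modest step beyond the scatter, which sets dimethylcarbamoyl apart from 2-fluoroethyl in this assay. No measurement at hand explains either result.

Open, on these data alone, is whether the fluorine in the 3-fluoropropyl side chain contributes at all, which a plain propyl chain on the shared core would test, and how far the chain can grow before the number shifts, as a longer chain such as 5-fluoropentyl would show. Also open, as far as these compounds go, is which part of dimethylcarbamoyl goes with the lower number of compound 2, a question that a primary amide, a simple ketone or a tertiary amine in its place would separate.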